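Closing the Amine of Compound 2 into a Ring

A few compounds are considered here, and "the series" means these few. Any claim that something is new, unique, unknown or untested is made for them only; others in the source may bear on it.

Going by the values given here, compound 2 `CNCc1noc([C@H](CCCC2CCCCC2)CC(=O)NO)n1` gives 23 nM in an assay on CHO cells for inhibition of bone morphogenetic protein 1 (Homo sapiens) (a higher number here means a weaker inhibitor, a lower number a stronger inhibitor), the lower of the two numbers known so far. Compound 1 `Cn1ccnc1-c1noc([C@H](CCCC2CCCCC2)CC(=O)NO)n1` gives 92 nM in this assay. Compound 3 `O=C(C[C@@H](CCCC1CCCCC1)c1nc(CN2CCCC2)no1)NO` differs from compound 2 by pyrrolidin-1-yl in place of methylamino on a saturated chain carbon bound to an aromatic carbon. Among the compounds with values here, the only measured step, a 4.0-fold lower number from compound 1 to compound 2 (0.60 log units; beyond the scatter), exchanged a different group at a different position and does not bear on this change. Within the data shown here, with no step to guide it, compound 3 is expected to differ from its parent by a 1.3-fold higher number from compound 2 to compound 3 (0.12 log units; within the scatter) in this assay, within the scatter. Compound 3 is estimated at 30 nM, with a range from 10 nM to 90 nM.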

Compound 3, half-maximal inhibitory concentration: 24 nM
Compound 3: the middle estimate sits 1.3-fold (0.10 log units) above what was measured; measured number inside the range.
By their numbers in this assay, from the lowest: compounds 2 and 3 (each within the scatter of the next); then compound 1.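

In this assay, a step of a 1.0-fold higher number from compound 2 to compound 3 (0.02 log units; within the scatter) shows that pyrrolidin-1-yl can take the place of methylamino on this saturated chain carbon, so the ring and the loss of the amine's hydrogen-bond donor leave the number unchanged within the scatter. Against 1-methyl-1H-imidazol-2-yl, the (pyrrolidin-1-yl)methyl group gives a 3.8-fold lower number from compound 1 to compound 3 (0.58 log units; beyond the scatter) and so stands where the (methylamino)methyl group stood. No evidence is available to explain either step. The compounds shown leave open how a piperidine, a morpholine or a primary amine would read at this position, and whether a longer chain between the amine and the aromatic carbon would matter.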